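A few compounds are considered here, and "the series" means these few. Any claim that something is new, unique, unknown or untested is made for them only; others in the source may bear on it.

In an ADME assay on Vero cells (Chlorocebus sabaeus) for cytotoxicity, read by MTT assay, with a stated time of 72 h (on this read-out lower numbers stand for higher toxicity in this test and higher numbers for lower toxicity in this test), the three measured compounds stand as follows.
Compound 1, `O[C@@H]1Cc2ccccc2N[C@H](c2ccccc2)C1`, gives > 300000 nM, which is a limit of this assay rather than a number.
Compound 2, `O[C@@H]1Cc2cc(Cl)ccc2N[C@H](c2ccccc2)C1`, gives 191000 nM.
Compound 3, `O[C@@H]1Cc2ccccc2N[C@H](c2ccc(Cl)cc2)C1`, gives > 300000 nM, again a limit rather than a number.

Compound 3 thus stands at the ceiling of what this assay reports, and the limit of > 300000 nM in this assay, at which 2 of the 3 values shown sit, is shared with compound 1, so only compound 2 provides a true number. The unmeasured compound 4, `O[C@@H]1Cc2cc(Cl)ccc2N[C@H](c2ccc(Cl)cc2)C1`, differs from compound 3 by chloro in place of hydrogen on an aromatic carbon. The same change made on compound 1 gave an at least 1.5-fold lower number from compound 1 to compound 2 (0.19 log units; that floor lies within the scatter). The other measured step, a step that the two limits leave unreadable from compound 1 to compound 3, cannot be sized. Because an at least 1.5-fold lower number from compound 1 to compound 2 (0.19 log units; that floor lies within the scatter) was small, a similarly small move toward a lower number is expected here, and the result may still come back as a limit. The expected step is an at least 1.5-fold lower number from compound 3 to compound 4 (0.17 log units; that floor lies within the scatter). Compound 4 is therefore estimated at 200000 nM, with a range from 90000 nM to 400000 nM.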

Compound 4, half-maximal cytotoxic concentration: 76600 nM
Estimate against measurement, compound 4: 2.6-fold (0.42 log units) above, outside the stated range (below it).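

In this assay, among the compounds shown here, where a lower number means higher toxicity, chloro in place of hydrogen at this position on the fused ring system gives an at least 3.9-fold lower number from compound 3 to compound 4 (0.59 log units; beyond the scatter), the first step for this position that clearly exceeds the usual scatter. The chloro already present in compound 3 also gets its first readable size, a 2.5-fold lower number from compound 2 to compound 4 (0.40 log units; beyond the scatter), so each of the two chloro groups lowers the number once the other is in place. Whether the change at this position has a larger effect on one core than on the other remains unsettled: the same change on two cores in this assay, an at least 1.5-fold lower number (0.19 log units; that floor lies within the scatter) from compound 1 to compound 2 and an at least 3.9-fold lower number (0.59 log units; beyond the scatter) from compound 3 to compound 4; the limit leaves it open whether they differ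

As far as these compounds go, the true values of the compounds at the limit remain unknown: the limit of > 300000 nM in this assay, at which 2 of the 4 values shown sit. It also remains open how the number would move with another group at this position, such as methoxy or an amine.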